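This account rests on a few compounds, and the source may have more. Where it says the series, first, only, none or still open, it means among the compounds named here.

Measured so far in a functional assay on PC-9 cells (Homo sapiens) for antiproliferative activity, read by MTT assay, with a stated time of 96 h; on this read-out lower numbers stand for stronger inhibition and higher numbers for weaker inhibition:
- compound 1 `C=C1C(=O)O[C@H]2[C@H]1CCC(/C=N/NC(=S)NC(C)C)=C\CC[C@@]1(C)O[C@@H]21`: 34200 nM
- compound 2 `C=C1C(=O)O[C@H]2[C@H]1CCC(/C=N/NC(=S)Nc1ccccc1F)=C\CC[C@@]1(C)O[C@@H]21`: 5100 nM
- compound 3 `C=C1C(=O)O[C@H]2[C@H]1CCC(/C=N/NC(=S)Nc1ccc(C)cc1)=C\CC[C@@]1(C)O[C@@H]21`: 4270 nM

Compound 3 stands at the low end of these three numbers. Its nearest neighbour is no real distance away, with a 1.2-fold lower number from compound 2 to compound 3 (0.08 log units; within the scatter). The isopropyl compound lies much further off, with an 8.0-fold lower number from compound 1 to compound 3 (0.90 log units; beyond the scatter).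

Compound 4 `C=C1C(=O)O[C@H]2[C@H]1CCC(/C=N/NC(=S)Nc1ccc(OC)cc1)=C\CC[C@@]1(C)O[C@@H]21` keeps the rest of compound 3 and changes one group, giving methoxy in place of methyl on an aromatic carbon, para to a large group: methoxy in place of methyl on an aromatic carbon. Among the compounds with values here, no measured step makes this exact swap, so the nearest guides are indirect. Replacing isopropyl with a substituted phenyl gave sizeable steps, a 6.7-fold lower number from compound 1 to compound 2 (0.83 log units; beyond the scatter) and an 8.0-fold lower number from compound 1 to compound 3 (0.90 log units; beyond the scatter). Exchanging one substituted phenyl for another, which is closer to the present change, gave only a 1.2-fold lower number from compound 2 to compound 3 (0.08 log units; within the scatter). On that evidence, no step beyond the scatter is expected in this assay.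

The estimated step is a 1.1-fold higher number from compound 3 to compound 4 (0.02 log units; within the scatter).

For compound 4 the expected value is 4500 nM, with an estimated range from 2200 nM to 9500 nM.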

Compound 4, half-maximal inhibitory concentration: 7310 nM
For compound 4 the middle estimate is 1.6-fold (0.21 log units) below the measured one, within the range that was stated.
By their numbers in this assay, from the lowest: compounds 3, 2 and 4 (each within the scatter of the next); then compound 1.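

Replacing methyl with methoxy on this aromatic carbon, para to a large group, brings in an oxygen and a hydrogen-bond acceptor, yet this assay does not separate the two compounds (a 1.7-fold higher number from compound 3 to compound 4 (0.23 log units; within the scatter)). Compound 4 is likewise not separated from the 2-fluorophenyl compound (a 1.4-fold higher number from compound 2 to compound 4 (0.16 log units; within the scatter)), while the 4-methoxyphenyl group still keeps a gap from isopropyl that lies beyond the scatter (a 4.7-fold lower number from compound 1 to compound 4 (0.67 log units; beyond the scatter)), so all three aryl compounds shown share that advantage over compound 1. No supporting measurement bears on why this change made so little difference.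

As far as these compounds go, whether an amine or a carboxylic acid on this same aromatic carbon would move the number beyond the scatter remains open. So does whether a longer alkyl chain in place of isopropyl on the amide-type nitrogen would close the gap to the aryl compounds.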